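A few compounds are considered here, and "the series" means these few. Any claim that something is new, unique, unknown or untested is made for them only; others in the source may bear on it.

In an ADME assay on a cell-free system (plasma, Mus musculus) for metabolic stability, read by LC-MS, tested at 2 uM (on this read-out lower numbers stand for a shorter-lived compound and higher numbers for a longer-lived compound), compound 2 `CC(=O)N1CCC(c2ccc3c(c2)oc(=O)n3C(=O)NCCCCc2ccccc2)CC1` gives 0.5 h, and compound 1 `CC(C)N1CCC(c2ccc3c(c2)oc(=O)n3C(=O)NCCCCc2ccccc2)CC1` gives 0.667 h. These two readings lie within the scatter of each other, so compound 2 stands level with compound 1. Compound 3 `O=C(NCCCCc1ccccc1)n1c2c(oc1=O)CNCC2` reads > 2 h, which is a limit of the assay and not a number. It differs from the other two in more than one place, so it offers no single step to reason from.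

Compound 4 `CN1CCC(c2ccc3c(c2)oc(=O)n3C(=O)NCCCCc2ccccc2)CC1=O` has not yet been measured. It carries 1-methyl-2-oxopiperidin-4-yl in place of 1-acetylpiperidin-4-yl on an aromatic carbon. Among the measured compounds shown here, only one measured step bears on this change: a 1.3-fold lower number from compound 1 to compound 2 (0.13 log units; within the scatter), with acetyl in place of isopropyl on an amine nitrogen in a ring. That step stayed within the scatter, so no clear rise or fall is expected in this assay this time either. The estimated step is a 1.1-fold higher number from compound 2 to compound 4 (0.04 log units; within the scatter). For compound 4 the estimated half-life is 0.55 h, with an expected range from 0.3 h to 1 h.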

Compound 4, half-life: 0.6 h
The estimate for compound 4 lay 1.1-fold (0.04 log units) below the measured number; the measured number falls inside the stated range.
By their numbers in this assay, from the lowest: compounds 2, 4 and 1 (each within the scatter of the next). At a limit, above all of these: compound 3.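

Until now, only the group on the ring nitrogen had been varied; here the carbonyl sits within the six-membered ring, with a methyl group on the nitrogen, and this assay shows a 1.2-fold higher number from compound 2 to compound 4 (0.08 log units; within the scatter). The comparison with the isopropyl-bearing compound gives the same picture, with a 1.1-fold lower number from compound 1 to compound 4 (0.05 log units; within the scatter). On this aromatic carbon, 1-isopropylpiperidin-4-yl, 1-acetylpiperidin-4-yl and 1-methyl-2-oxopiperidin-4-yl therefore all stand level in this assay, so moving the carbonyl from outside the ring to inside it makes no clear difference to the half-life.

Nothing given here accounts for why these three groups read alike. Still open, from the compounds shown here alone, is whether a carboxylic acid on this ring, or a longer chain on its nitrogen, would read level with them too.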